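Swapping a hydroxyphenyl on a pyridine-like core

A few compounds are considered here, and "the series" means these few. Any claim that something is new, unique, unknown or untested is made for them only; others in the source may bear on it.

Compound 1 `Oc1ccc(-c2cc(-c3cccc(O)c3)nc(-c3cccc(O)c3)c2)cc1` and compound 3 `Oc1cccc(-c2cc(-c3ccccc3O)cc(-c3cccc(O)c3)n2)c1` share a core and differ in one group. In a functional assay on HCT-15 cells (Homo sapiens) for cytotoxicity, read by CCK-8 assay, with a stated time of 4 days (a lower number here means a stronger inhibitor, a higher number a weaker inhibitor), compound 1 gives 3810 nM, and compound 3 gives 5150 nM. The change 4-hydroxyphenyl in place of 2-hydroxyphenyl on an aromatic carbon produced a 1.4-fold lower number from compound 3 to compound 1 (0.13 log units; within the scatter). Compound 2 `Oc1cccc(-c2cc(-c3cccc(O)c3)nc(-c3ccccc3O)c2)c1` reaches only a limit in this assay, > 50000 nM; this is the limit of > 50000 nM in this assay, at which 1 of the 3 values shown sits. How the core of compound 2 differs from the core of compound 3 is not broken down here. Compound 4 `Oc1ccc(-c2cc(-c3cccc(O)c3)cc(-c3cccc(O)c3)n2)cc1` is not yet measured. It arises from compound 2 by 4-hydroxyphenyl in place of 2-hydroxyphenyl on an aromatic carbon, the same kind of change as before, though here the group sits next to the ring nitrogen rather than opposite the ring nitrogen. Beside a 1.4-fold lower number from compound 3 to compound 1 (0.13 log units; within the scatter), the step is expected to be an at least 1.2-fold lower number from compound 2 to compound 4 (0.09 log units; that floor lies within the scatter). Compound 4 is therefore estimated at 40000 nM, likely between 12000 nM and 150000 nM.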

Compound 4, half-maximal inhibitory concentration: 3090 nM
Compound 4: the middle estimate sits 13-fold (1.11 log units) above what was measured; the whole stated range lies above it.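

On the core of compound 2, with the group next to the ring nitrogen, 4-hydroxyphenyl in place of 2-hydroxyphenyl gives an at least 16-fold lower number from compound 2 to compound 4 (1.20 log units; beyond the scatter) in this assay. The change therefore does not carry over as one fixed step from core to core: the same change on two cores in this assay, a 1.4-fold lower number (0.13 log units; within the scatter) from compound 3 to compound 1 and an at least 16-fold lower number (1.20 log units; beyond the scatter) from compound 2 to compound 4, at least 11-fold (1.07 log units) apart, beyond the scatter of two such steps The value of compound 2, > 50000 nM, is a limit of the assay and not a number, so the real size of this step stays unknown, and nothing here shows why the two cores differ.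

All the compounds shown carry only hydroxyphenyl groups. From the compounds shown here alone, whether the same difference between cores would appear with a methoxy group or an amine in place of the hydroxyl remains open.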